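This account rests on a few compounds, and the source may have more. Where it says the series, first, only, none or still open, it means among the compounds named here.

Measured compounds:
compound 1 `Nc1ccccc1NC(=O)c1ccc(CSC(=S)N2CCN(C(c3ccccc3)c3ccccc3)CC2)cc1`: 9.9%
compound 2 `CN(Cc1ccncc1)C(=S)SCc1ccc(C(=O)Nc2ccccc2N)cc1`: 83.2%

In a functional assay on MGC-803 cells (Homo sapiens) for antiproliferative activity, read by CCK-8 assay, with a stated time of 72 h, tested at 8 uM (a higher number here means a stronger effect of the compound at the concentration tested, a lower number a weaker effect), compound 2 stands highest of the two, and compound 1 lies far below it. Compound 3 `CN1CCN(C(=S)SCc2ccc(C(=O)Nc3ccccc3N)cc2)CC1` has not been measured; it carries 4-methylpiperazin-1-yl in place of methyl((pyridin-4-yl)methyl)amino on a thiocarbonyl carbon. Among the measured compounds shown here, no step between measured compounds bears on this change, so the expectation rests on compound 2 alone. A downward step from compound 2 to compound 3 of about a number 38.2 percentage points lower from compound 2 to compound 3 (beyond the scatter) is expected, beyond the scatter. Compound 3 is estimated at 45%, within 10% to 85%.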

Compound 3, a percentage reported as inhibition, at one concentration (the size of the read-out at that concentration, not a potency): 84.4%
Compound 3: middle estimate off by 39.4 percentage points, on the low side; the measured number falls inside the stated range.
By their numbers in this assay, from the lowest: compound 1; then compounds 2 and 3 (each within the scatter of the next).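

In this assay, replacing methyl((pyridin-4-yl)methyl)amino with 4-methylpiperazin-1-yl on a thiocarbonyl carbon gives a number 1.2 percentage points higher from compound 2 to compound 3 (within the scatter). The aromatic ring of the group that leaves is therefore not needed for this level of inhibition, as a non-aromatic ring serves equally well at this position. Nothing available accounts for this equivalence. Still open, as far as these compounds go, is how a morpholine ring would fare on the thiocarbonyl carbon. Also open, from the compounds shown here alone, is how an ethyl or benzyl group would compare with the methyl of 4-methylpiperazin-1-yl.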